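The source may hold more compounds than are shown below. What is called first, only, known or untested is meant among the compounds shown, and "the series" means these compounds.

Measured compounds in a functional assay on HeLa cells (Homo sapiens) for antiproliferative activity, read by CCK-8 assay, with a stated time of 72 h, tested at 8 uM; a higher number here means a stronger effect of the compound at the concentration tested, a lower number a weaker effect:
compound 1 `Nc1ccccc1NC(=O)c1ccc(CSC(=S)N2CCN(c3ccccc3)CC2)cc1` gives 73.1%
compound 2 `Nc1ccccc1NC(=O)c1ccc(CSC(=S)N2CCN(c3ccc(F)cc3)CC2)cc1` gives 64.5%
compound 3 `Nc1ccccc1NC(=O)c1ccc(CSC(=S)N2CCN(Cc3ccncc3)CC2)cc1` gives 72.9%

Compound 3 sits among the other two without separating from either: its nearest neighbour is compound 1, a number 0.2 percentage points lower from compound 1 to compound 3 (within the scatter), and its furthest is compound 2, a number 8.4 percentage points higher from compound 2 to compound 3 (within the scatter), both within the scatter. The three values in this assay therefore form one group at roughly the same level.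

Compound 4 `Nc1ccccc1NC(=O)c1ccc(CSC(=S)N2CCN(c3ccncc3)CC2)cc1` differs from compound 3 only at the amine nitrogen in the ring: pyridin-4-yl in place of (pyridin-4-yl)methyl on an amine nitrogen in a ring. The steps that touch this position are a number 0.2 percentage points lower from compound 1 to compound 3 (within the scatter) and a number 8.4 percentage points higher from compound 2 to compound 3 (within the scatter), each within the scatter, and the remaining step of a number 8.6 percentage points lower from compound 1 to compound 2 (within the scatter) concerns a different place and is also within the scatter. No change at the ring nitrogen examined so far has moved the read-out beyond the scatter, so for the new substituent no step beyond the scatter in either direction is expected; the expected step is a number 2.9 percentage points lower from compound 3 to compound 4 (within the scatter).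

Compound 4 is estimated at 70%, with a range from 58% to 80%.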

Compound 4, a percentage reported as inhibition, at one concentration (the size of the read-out at that concentration, not a potency): 77.4%
Compound 4: the middle estimate sits 7.4 percentage points below what was measured, within the range that was stated.
By their numbers in this assay, from the lowest: compounds 2, 3, 1 and 4 (each within the scatter of the next, the first and the last beyond it).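

At the amine nitrogen in the ring, this assay now shows its first step beyond the scatter, a modest one, with pyridin-4-yl in place of 4-fluorophenyl (a number 12.9 percentage points higher from compound 2 to compound 4 (beyond the scatter)). The same group does not separate from (pyridin-4-yl)methyl (a number 4.5 percentage points higher from compound 3 to compound 4 (within the scatter)) or from phenyl (a number 4.3 percentage points higher from compound 1 to compound 4 (within the scatter)), so at this position the separation holds only against 4-fluorophenyl. No measurement on hand gives a reason for this separation.

From the compounds shown here alone, whether pyridin-3-yl, pyridin-2-yl or a longer chain such as 2-(pyridin-4-yl)ethyl on this nitrogen would keep the read-out at this level remains open. These single-concentration read-outs also leave open how the compounds rank in potency.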